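The source may hold more compounds than are shown below. What is called first, only, known or untested is meant among the compounds shown, and "the series" means these compounds.

Compound 2 `CC(C(=O)c1cc(C(F)(F)F)nn1-c1ccc2onc(N)c2c1)c1ccc(-c2ccccc2S(N)(=O)=O)cc1` has been tested in an assay on isolated protein for inhibition of Trypsin (Homo sapiens); a higher number here means a weaker inhibitor, a lower number a stronger inhibitor. In this assay compound 2 gives > 20000 nM, which is a limit of the assay rather than a number. Its close relative compound 3 `CC(C(=O)c1cc(C(F)(F)F)nn1-c1ccc2onc(N)c2c1)c1ccc(-c2ccccc2S(C)(=O)=O)cc1` is also known only to a limit: in this assay compound 3 gives > 20000 nM. The one-place step between them, a step that the two limits leave unreadable from compound 2 to compound 3, is the methyl in place of amino on a sulfonyl sulfur and cannot be read because both ends are limits (the limit of > 20000 nM in this assay, at which 2 of the 3 values shown sit). A third member of the series, compound 1 `COc1ccc(-n2nc(C(F)(F)F)cc2C(=O)Cc2ccc(-c3ccccc3S(N)(=O)=O)cc2)cc1`, is likewise known only to a limit; in this assay compound 1 gives > 2500 nM, a limit of the assay.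

The next compound, compound 4 `Nc1noc2ccc(-n3nc(C(F)(F)F)cc3C(=O)Cc3ccc(-c4ccccc4S(N)(=O)=O)cc3)cc12`, differs from compound 2 by hydrogen in place of methyl on a saturated chain carbon bound to an aromatic carbon and a carbonyl carbon. For the measured compounds named here, no measured step touches this change. All three values shown are limits the limit of > 20000 nM in this assay, at which 2 of the 3 values shown sit (the limit of > 2500 nM in this assay, at which 1 of the 3 values shown sits), so no direction and no size can be drawn from them beyond the expectation that compound 4 also stays weak. Compound 4 is therefore expected to give about 20000 nM in this assay, within a range of 5000 nM to 100000 nM. The step of a number no higher from compound 2 to compound 4 (the limit leaves the size open) that this estimate means is expected to lie within the scatter.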

Compound 4, inhibition constant: > 20000 nM
Compound 4 gave a limit, no number (the forecaster's own chance of this, stated with the estimate: 85%); the middle value lies on the limit itself.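

In this assay compound 4 gives > 20000 nM, a limit of the assay and not a number. Compound 1 and compound 2 are also known only to limits, so neither of their steps to compound 4 can be read. The compounds shown leave open what any of these changes does in this assay.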